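This account rests on a few compounds, and the source may have more. Where it says the series, first, only, none or still open, it means among the compounds named here.

Three compounds sharing one core differ only in a single group on an aromatic carbon, and all have been measured in a functional assay on HeLa cells (Homo sapiens) for inhibition, read by CCK-8 assay, with a stated time of 48 h; on this read-out lower numbers stand for stronger inhibition and higher numbers for weaker inhibition. The fluoro compound 1 (`COc1cc(-c2ccnc3cc(-c4ccc(F)cc4)nn23)cc(OC)c1OC`) gives 5840 nM, the chloro compound 2 (`COc1cc(-c2ccnc3cc(-c4ccc(Cl)cc4)nn23)cc(OC)c1OC`) gives 1490 nM, and the methyl compound 3 (`COc1cc(-c2ccnc3cc(-c4ccc(C)cc4)nn23)cc(OC)c1OC`) gives 21 nM, the lowest number of the three. Compound 4 (`COc1cc(-c2ccnc3cc(-c4ccc(C)c(C)c4)nn23)cc(OC)c1OC`) keeps that methyl and gains a second one, turning 4-methylphenyl into 3,4-dimethylphenyl: methyl in place of hydrogen on an aromatic carbon. This is methyl in place of hydrogen on an aromatic carbon, ortho to a methyl group and meta to a large group.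

The measured steps bear on this only indirectly, since each swaps one group at a single carbon and none adds a group at the new place. They do show how far one swap can move the number. a 3.9-fold lower number from compound 1 to compound 2 (0.59 log units; beyond the scatter) is modest, while a 280-fold lower number from compound 1 to compound 3 (2.44 log units; beyond the scatter) and a 71-fold lower number from compound 2 to compound 3 (1.85 log units; beyond the scatter) are large. Compound 3, at 21 nM, already sits at the low end, so a moderate rise in this assay is expected, with a wide margin in either direction. The expected change is a 2.9-fold higher number from compound 3 to compound 4 (0.46 log units; beyond the scatter). Compound 4 is estimated at 60 nM, with an expected range from 10 nM to 500 nM.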

Compound 4, half-maximal inhibitory concentration: 241 nM
Estimate against measurement, compound 4: 4.0-fold (0.60 log units) below; the measured number falls inside the stated range.
By their numbers in this assay, from the lowest: compound 3; then compound 4; then compound 2; then compound 1.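

In this assay, among the compounds shown here, the earlier steps only swapped one group at a single carbon, whereas this change adds a methyl ortho to a methyl group and meta to a large group, and it gives an 11-fold higher number from compound 3 to compound 4 (1.06 log units; beyond the scatter) as a large step in the unfavourable direction. So this carbon, which carries hydrogen in compound 3, does not take a methyl without a clear loss, although compound 4 still gives a 6.2-fold lower number from compound 2 to compound 4 (0.79 log units; beyond the scatter) and a 24-fold lower number from compound 1 to compound 4 (1.38 log units; beyond the scatter) and so stays ahead of both halogen compounds, with the 4-methylphenyl of compound 3 keeping the lowest number of the four. Nothing given here accounts for the rise caused by the second methyl.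

The compounds shown leave open whether any group at this place raises the number or whether this is particular to methyl, as fluoro, methoxy and hydroxyl at this carbon are not among them. For the compounds shown here, they also leave open whether the added methyl would have the same effect alongside the chloro or fluoro group, and whether an ethyl group in place of the single methyl of compound 3 would keep its low number.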